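Pyridinyl for ethoxyphenyl on a shared core

A few compounds are considered here, and "the series" means these few. Any claim that something is new, unique, unknown or untested is made for them only; others in the source may bear on it.

Compound 1 `Fc1ccccc1Nc1nc2nonc2nc1Nc1ccccc1` and compound 2 `CCOc1ccc(Nc2nc3nonc3nc2Nc2ccccc2F)cc1` share one core. In an assay on mitochondria from L6 cells (Rattus norvegicus) for activation, with a stated time of 90 min (on this read-out higher numbers stand for an effect only at larger amounts of compound and lower numbers for an effect already at smaller amounts), compound 1 gives 2200 nM, and compound 2 gives 3800 nM. The step of a 1.7-fold higher number from compound 1 to compound 2 (0.24 log units; within the scatter) lies within the scatter, though the number of compound 2 stands highest of the two shown. Compound 3 `Fc1ccccc1Nc1nc2nonc2nc1Nc1ccccn1` carries pyridin-2-yl in place of 4-ethoxyphenyl on a nitrogen on an aromatic ring. Among the measured compounds shown here, no measured step touches this exchange; the only recorded step concerns an ethoxy group and offers no guide. For compound 3 the estimated step is a 1.3-fold lower number from compound 2 to compound 3 (0.10 log units; within the scatter). Compound 3 is therefore expected to give 3000 nM in this assay, within 700 nM to 13000 nM.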

Compound 3, half-maximal effective concentration: 9000 nM
Compound 3: the middle estimate sits 3.0-fold (0.48 log units) below what was measured; low and high end bracket the measured number.
By their numbers in this assay, from the lowest: compounds 1 and 2 (each within the scatter of the next); then compound 3.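

In this assay pyridin-2-yl on this nitrogen shows a 2.4-fold higher number from compound 2 to compound 3 (0.37 log units; beyond the scatter) against 4-ethoxyphenyl and a 4.1-fold higher number from compound 1 to compound 3 (0.61 log units; beyond the scatter) against phenyl. Compound 1 and compound 2 had stayed within the scatter of each other, so among these three groups only pyridin-2-yl stands apart, toward larger amounts of compound. Nothing available explains this shift. On these data alone, whether pyridin-3-yl or pyridin-4-yl would read like pyridin-2-yl remains open. So does how an amine or a carboxylic acid on the phenyl ring would read.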